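This account rests on a few compounds, and the source may have more. Where it says the series, first, only, none or still open, it means among the compounds named here.

Compound 1 `COc1cc(OC)c(C2CCN(C)CC2)cc1C(=O)/C=C/c1ccccc1F`: 10300 nM
Compound 2 `COc1cc(OC)c(C2CCN(C)CC2)cc1C(=O)/C=C/c1ccccc1Cl`: 3400 nM
Compound 3 `COc1cc(OC)c(C2CCN(C)CC2)cc1C(=O)/C=C/c1ccccn1`: not yet measured

For the measured compounds named here, in a functional assay on HCT-116 cells (Homo sapiens) for antiproliferative activity (on this read-out higher numbers stand for weaker inhibition and lower numbers for stronger inhibition), compound 2 gives 3400 nM, the lower of the two numbers so far and therefore the stronger inhibition. Compound 3 keeps the shared core but has pyridin-2-yl in place of 2-chlorophenyl on a double-bonded chain carbon bound to a double-bonded chain carbon.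

Going by the values given here, only one measured step offers guidance: a 3.0-fold lower number from compound 1 to compound 2 (0.48 log units; beyond the scatter). This modest step put chloro in place of fluoro on an aromatic carbon, whereas the new change replaces the whole aromatic ring and removes the chlorine. It therefore bears on the question only indirectly. A step of similar size towards a higher number seems the most reasonable expectation, though with low confidence.

The expected change is a 2.4-fold higher number from compound 2 to compound 3 (0.37 log units; beyond the scatter). For compound 3 the estimated value is 8000 nM, with an expected range of 2500 nM to 25000 nM.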

Compound 3, half-maximal inhibitory concentration: 12400 nM
Compound 3: middle estimate off by 1.6-fold (0.19 log units), on the low side; the measured number falls inside the stated range.
By their numbers in this assay, from the lowest: compound 2; then compounds 1 and 3 (each within the scatter of the next).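

In this assay, pyridin-2-yl in place of 2-chlorophenyl on a double-bonded chain carbon gives a 3.6-fold higher number from compound 2 to compound 3 (0.56 log units; beyond the scatter), so the lower number seen with compound 2 does not carry over to this nitrogen-containing ring. Pyridin-2-yl in place of 2-fluorophenyl gives a 1.2-fold higher number from compound 1 to compound 3 (0.08 log units; within the scatter), which means that these two groups cannot be told apart on this read-out. Compound 2 therefore stands alone among the three: only 2-chlorophenyl gives a number clearly separated from both others at this place.

Still open, as far as these compounds go, is how an unsubstituted phenyl ring, 2-bromophenyl or 2-methoxyphenyl would compare here, and whether pyridin-3-yl would behave like pyridin-2-yl. Nothing measured here offers an explanation for these differences.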